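Three Weak Dopamine Transporter Binders and a Fluorinated Variant

The source may report more compounds than this note shows. Statements on the series, on what has been measured and on what is new or still open speak of the compounds shown alone.

Compound 1 `COC(=O)C1=C(c2cccc(N)c2)CCC1`, compound 2 `COC(=O)C1=C(c2ccccc2)CCCC1` and compound 3 `COC(=O)[C@@H]1CCCC[C@@H]1c1ccc(C(C)(C)C)cc1` are closely related methyl esters that differ in the substituent on their aromatic ring and in the size of the shared core. In an assay on COS-1 cells for displacement of a labelled ligand from sodium-dependent dopamine transporter (Homo sapiens) (a higher number here means a weaker inhibitor, a lower number a stronger inhibitor), compound 1 gives 875000 nM, compound 2 gives 630000 nM and compound 3 gives 766000 nM. Compound 3 stands second highest of the three numbers; its nearest neighbour is compound 1 and its furthest is compound 2, and both gaps lie within the usual scatter of repeated measurements, so the three compounds cannot be told apart on these data.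

Compound 4 `COC(=O)[C@@H]1CCCC[C@@H]1c1ccc(OC(F)(F)F)cc1` has not yet been measured in this assay. Relative to compound 3 it carries trifluoromethoxy in place of tert-butyl on an aromatic carbon. Within the data shown here, no measured pair in this set shows what such an exchange does, so there is no direct precedent for it. Because compound 1 gives 875000 nM and compound 2 gives 630000 nM despite their different substituents, the whole series appears insensitive to the aromatic substituent. Compound 4 is therefore expected to stay in the same region, with an estimated step of a 1.1-fold lower number from compound 3 to compound 4 (0.04 log units; within the scatter) that does not go beyond the scatter. The estimate for compound 4 in this assay is 700000 nM, with a range from 250000 nM to 2000000 nM.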

Compound 4, inhibition constant: 1180000 nM
Beside the measured number, compound 4's estimate is 1.7-fold (0.23 log units) below it; measured number inside the range.
By their numbers in this assay, from the lowest: compounds 2, 3, 1 and 4 (each within the scatter of the next).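

Compound 3 and compound 4 give the first direct view of a substituent exchange at this place, on an aromatic carbon para to a large group. In this assay, putting trifluoromethoxy in place of tert-butyl gives a 1.5-fold higher number from compound 3 to compound 4 (0.19 log units; within the scatter) and so does not separate the two compounds. Tert-butyl is made only of carbon, whereas trifluoromethoxy brings in oxygen, fluorine and a hydrogen-bond acceptor, yet this difference in makeup produces no step that can be told apart from repeat-measurement noise, and no measurement bearing on the reason for this result is available.

Going by these compounds, it remains open whether a group of another kind at this place, such as a carboxylic acid or a sulfonamide, would move the number beyond the scatter. Every compound shown carries the methyl ester, so what an amide in its place would do is a separate question that these numbers cannot answer.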